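This account rests on a few compounds, and the source may have more. Where it says the series, first, only, none or still open, it means among the compounds named here.

Measured in a functional assay on the whole organism with Scenedesmus acutus as the target, read by spectrophotometry; a lower number here means a stronger inhibitor, a higher number a weaker inhibitor:
- compound 1 `Cc1cc(Cl)ccc1/N=c1\sc(=S)n2n1CCCC2` gives 275 nM
- compound 2 `CC(C)Oc1cc(-n2c(=S)n3n(c2=S)CCCC3)c(F)cc1Cl` gives 5.25 nM
- compound 3 `S=c1n(-c2ccc(OCc3ccc(Cl)cc3)cc2)c(=S)n2n1CCCC2` gives 15.5 nM

Compound 2 holds the lowest of these three numbers, and its gaps to compound 3 and to compound 1 both lie beyond the scatter. Among the measured compounds shown here, no two measured compounds differ in one place only, so no direct step is available as a guide.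

Compound 4 `Fc1cc(Cl)ccc1-n1c(=S)n2n(c1=S)CCCC2` has not yet been measured. Its difference from compound 2 is hydrogen in place of isopropoxy on an aromatic carbon (hydrogen in place of isopropoxy on an aromatic carbon, ortho to a chloro group and para to a fluoro group).

A higher number is expected in this assay, beyond the scatter. The support is thin: compound 1 lacks isopropoxy and stands at 275 nM on a different core. Compound 3 goes against any simple link, since it also lacks isopropoxy yet gives 15.5 nM in the same assay. The range is therefore kept wide.

The estimated change is an 11-fold higher number from compound 2 to compound 4 (1.06 log units; beyond the scatter) as the expected step. Compound 4 is estimated at 60 nM in this assay with 15 nM to 250 nM as the expected range.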

Compound 4, half-maximal inhibitory concentration: 18.2 nM
The estimate for compound 4 lay 3.3-fold (0.52 log units) above the measured number; low and high end bracket the measured number.
By their numbers in this assay, from the lowest: compound 2; then compounds 3 and 4 (each within the scatter of the next); then compound 1.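

In this assay, among the compounds shown here, this is the first direct reading at this position on the shared core. Hydrogen in place of isopropoxy on the aromatic carbon, ortho to a chloro group and para to a fluoro group, gives a 3.5-fold higher number from compound 2 to compound 4 (0.54 log units; beyond the scatter). The step is beyond the scatter, so the choice of group here does register, yet isopropoxy is not needed for a low number, since compound 4, with hydrogen at this place, still gives 18.2 nM in this assay. Nothing available bears on why the number moves with this change.

For the compounds shown here, only two groups have been compared at this position, so it remains open whether a methoxy group, a longer alkoxy chain such as butoxy, or an amine would give a number nearer that of compound 2 or that of compound 4. On these data alone, it also remains open whether the same exchange would give a step of similar size on the core of compound 1, or on an aromatic ring without the chloro and fluoro groups.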